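Hydroxyphenyl-substituted pyridine series: topoisomerase inhibition notes

This account rests on a few compounds, and the source may have more. Where it says the series, first, only, none or still open, it means among the compounds named here.

Measured so far:
compound 1, `Oc1ccc(-c2cc(-c3ccccc3O)cc(-c3cccc(O)c3)n2)cc1`, 0%
compound 2, `Oc1ccc(-c2cc(-c3cccc(O)c3)nc(-c3cccc(O)c3)c2)cc1`, 0%

In an assay on isolated protein for inhibition of DNA topoisomerase 1 (Homo sapiens), with a stated time of 30 min, tested at 100 uM (on this read-out lower numbers stand for less inhibition and higher numbers for more inhibition at the one concentration tested (going by the name of the read-out)), compound 1 gives 0%. Compound 2 gives 0% in this assay, level with compound 1 at the digits shown, so the two stand together within the scatter.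

Compound 3, `Oc1ccc(-c2cc(-c3ccc(O)cc3)nc(-c3cccc(O)c3)c2)cc1`, is not yet measured. It differs from compound 2 in one place: 4-hydroxyphenyl in place of 3-hydroxyphenyl on an aromatic carbon. A 3-hydroxyphenyl group leaves and a 4-hydroxyphenyl group enters on an aromatic carbon of a six-membered aromatic ring with 1 nitrogen.

With both measured compounds flat in this assay, no step beyond the scatter is expected; the expected step of no change at the digits printed from compound 2 to compound 3 (within the scatter) is essentially none. Compound 3 is therefore estimated at 0%, with a range from 0% to 10%.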

Compound 3, a percentage reported as inhibition, at one concentration (the size of the read-out at that concentration, not a potency): 0%
Estimate against measurement, compound 3: no gap at the digits printed, and the stated range covers the measured number.
By their numbers in this assay, from the lowest: compounds 1, 2 and 3 (each within the scatter of the next).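

Replacing 3-hydroxyphenyl with 4-hydroxyphenyl next to the ring nitrogen gives no change at the digits printed from compound 2 to compound 3 (within the scatter) in this assay at the one concentration tested. Replacing 2-hydroxyphenyl with 4-hydroxyphenyl gives no change at the digits printed from compound 1 to compound 3 (within the scatter) in the same read-out, so neither exchange of hydroxyphenyl isomers separates these compounds. No supporting data bear on this flat result.

On these data alone, whether any compound on the shared core registers inhibition remains open. An amine or a carboxylic acid in place of a hydroxyphenyl group also remains to be compared.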